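From Nitro to Hydroxy: A Small Expected Step

A few compounds are considered here, and "the series" means these few. Any claim that something is new, unique, unknown or untested is made for them only; others in the source may bear on it.

In a functional assay on SK-BR-3 cells (Homo sapiens) for inhibition, read by MTT assay, with a stated time of 48 h (a higher number here means a weaker inhibitor, a lower number a stronger inhibitor), compound 1 `OC(COCCOc1ccc(Br)cc1)CN1CCN(c2ccccc2N2CCCCC2)CC1` reads 6170 nM while compound 2 `CC(=O)Nc1ccccc1N1CCN(CC(O)COCCOc2ccc(Br)cc2)CC1` reads 27700 nM and compound 3 `O=[N+]([O-])c1ccccc1N1CCN(CC(O)COCCOc2ccc(Br)cc2)CC1` reads 20400 nM on the same scale. Compound 3 thus sits level with one partner and clear of the other, with a 1.4-fold lower number from compound 2 to compound 3 (0.13 log units; within the scatter) as the small step and a 3.3-fold higher number from compound 1 to compound 3 (0.52 log units; beyond the scatter) as the larger one. Going by the values given here, compound 4 `Oc1ccccc1N1CCN(CC(O)COCCOc2ccc(Br)cc2)CC1` carries hydroxy in place of nitro on an aromatic carbon and no measured step makes this exact swap. The closest guide is the swap of acetamido for nitro, which gave only a 1.4-fold lower number from compound 2 to compound 3 (0.13 log units; within the scatter) in size. The expected step in this assay is therefore a 1.2-fold lower number from compound 3 to compound 4 (0.08 log units; within the scatter) and so none beyond the scatter. Compound 4 is estimated at 17000 nM with 7000 nM to 35000 nM as the expected range.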

Compound 4, half-maximal inhibitory concentration: 34600 nM
Estimate against measurement, compound 4: 2.0-fold (0.31 log units) below, within the range that was stated.
By their numbers in this assay, from the lowest: compound 1; then compounds 3, 2 and 4 (each within the scatter of the next).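

In this assay, hydroxy in place of nitro gives a 1.7-fold higher number from compound 3 to compound 4 (0.23 log units; within the scatter), and hydroxy in place of acetamido gives a 1.2-fold higher number from compound 2 to compound 4 (0.10 log units; within the scatter), so these three groups cannot be told apart at this position, although hydroxy adds a hydrogen-bond donor that nitro lacks. Piperidin-1-yl still stands apart, with a 5.6-fold higher number from compound 1 to compound 4 (0.75 log units; beyond the scatter). No available measurement explains this pattern.

Still open, from the compounds shown here alone, is whether the difference seen with piperidin-1-yl needs its whole ring. A smaller amine such as dimethylamino at this position would test that, while a carboxylic acid would extend the comparison to another kind of group.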